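This account rests on a few compounds, and the source may have more. Where it says the series, first, only, none or still open, it means among the compounds named here.

Measured compounds:
compound 1 `CC(C(=O)NCc1ccc(C(F)(F)F)cc1N1CCCC1)c1ccc(NS(C)(=O)=O)c(F)c1` — 2.3 nM
compound 2 `CC(C(=O)NCc1ccc(C(F)(F)F)cc1N1CCC(Cc2ccc(F)cc2)CC1)c1ccc(NS(C)(=O)=O)c(F)c1` — 0.4 nM

Working notes. In an assay on CHO cells for antagonist activity at transient receptor potential cation channel subfamily V member 1 (Homo sapiens), read by FLIPR (on this read-out higher numbers stand for weaker inhibition and lower numbers for stronger inhibition), compound 1 gives 2.3 nM, the highest of the two numbers recorded. Compound 2 gives 0.4 nM in this assay, a lower number, and the gap between compound 1 and compound 2 lies beyond the scatter. For the measured compounds named here, the two compounds share one core and no single-change pair between measured compounds is available.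

Compound 3 `CC(C(=O)NCc1ccc(C(F)(F)F)cc1OC1CCCCC1)c1ccc(NS(C)(=O)=O)c(F)c1` has not yet been measured in this assay. Against compound 1 the change is cyclohexyloxy in place of pyrrolidin-1-yl on an aromatic carbon. Going by the values given here, no measured step isolates this exchange, so the expectation rests on compound 1 alone, with the note that the one other variation at this place, compound 2, gave 0.4 nM. The expected step is small, within the scatter, tilted if at all toward a lower number. Compound 3 is expected at 1.5 nM in this assay, in the range 0.4 nM to 6 nM, which means an expected step of a 1.5-fold lower number from compound 1 to compound 3 (0.19 log units; within the scatter).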

Compound 3, inhibition constant: 0.7 nM
Estimate against measurement, compound 3: 2.1-fold (0.33 log units) above; the measured number falls inside the stated range.
By their numbers in this assay, from the lowest: compounds 2 and 3 (each within the scatter of the next); then compound 1.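

In this assay, for the compounds shown here, cyclohexyloxy in place of pyrrolidin-1-yl on this aromatic carbon gives a 3.3-fold lower number from compound 1 to compound 3 (0.52 log units; beyond the scatter), the first single exchange at this place that can be read, and it runs toward stronger inhibition. The result also shows that attachment through nitrogen is not required at this place for inhibition at this level, since compound 3 carries oxygen there and a ring of carbon only. No measurement at hand accounts for the step.

The exchange alters the attached atom and the ring size together, so the share of each cannot be separated. Also open, on these data alone, is how cyclopentyloxy, which would keep the oxygen with a five-membered ring, or an open-chain amine such as diethylamino would read at this place.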